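Adding a bromo group to a second fluorophenyl pair

This account rests on a few compounds, and the source may have more. Where it says the series, first, only, none or still open, it means among the compounds named here.

Measured so far:
Compound 1 `O=C(C1COc2ccccc2O1)N1N=C(c2ccccc2)CC1c1cccc(F)c1` gives 1450 nM.
Compound 2 `O=C(C1COc2ccccc2O1)N1N=C(c2ccc(Br)cc2)CC1c1cccc(F)c1` gives 7810 nM.
Compound 3 `O=C(C1COc2ccccc2O1)N1N=C(c2ccccc2)CC1c1ccc(F)cc1` gives 3270 nM.

These three compounds share one scaffold and were tested in a functional assay on WM 266-4 cells (Homo sapiens) for inhibition, read by MTT assay, with a stated time of 24 h; a lower number here means a stronger inhibitor of growth, a higher number a weaker inhibitor of growth. Compound 1 and compound 2 differ by a single group: bromo in place of hydrogen on an aromatic carbon. That change made the step of a 5.4-fold higher number from compound 1 to compound 2 (0.73 log units; beyond the scatter), so the growth inhibition became weaker.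

Compound 1 and compound 3 differ in where the fluorine sits on the pendant ring: 4-fluorophenyl in place of 3-fluorophenyl on a saturated ring carbon. This gave the step of a 2.3-fold higher number from compound 1 to compound 3 (0.35 log units; beyond the scatter), again a weakening, though smaller.

Compound 4 `O=C(C1COc2ccccc2O1)N1N=C(c2ccc(Br)cc2)CC1c1ccc(F)cc1` has not yet been measured. It relates to compound 3 exactly as compound 2 relates to compound 1: bromo in place of hydrogen on an aromatic carbon. The place of the change is the same in both pairs word for word, so this is the same change, applied here to a 4-fluorophenyl rather than a 3-fluorophenyl core.

Going by the values given here, with only one earlier example of this change, the expectation rests on compound 1 and compound 2 and their step of a 5.4-fold higher number from compound 1 to compound 2 (0.73 log units; beyond the scatter), carried over to compound 3. The expected step is a 4.6-fold higher number from compound 3 to compound 4 (0.66 log units; beyond the scatter). Compound 4 is therefore estimated at 15000 nM, with a range from 6000 nM to 40000 nM to allow for the change behaving somewhat differently on a different core.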

Compound 4, concentration for 50% growth inhibition: 5630 nM
Compound 4: the middle estimate sits 2.7-fold (0.43 log units) above what was measured, and the stated range ends above it.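

In this assay, putting bromo in place of hydrogen on the 4-fluorophenyl core gave a 1.7-fold higher number from compound 3 to compound 4 (0.24 log units; within the scatter), so this change did not keep its size from one core to the other: the same change on two cores in this assay, a 5.4-fold higher number (0.73 log units; beyond the scatter) from compound 1 to compound 2 and a 1.7-fold higher number (0.24 log units; within the scatter) from compound 3 to compound 4, 3.1-fold (0.50 log units) apart, beyond the scatter of two such steps. Replacing 3-fluorophenyl with 4-fluorophenyl, with the bromo already present, gave a 1.4-fold lower number from compound 2 to compound 4 (0.14 log units; within the scatter), and this change also depended on its surroundings: the same change on two cores in this assay, a 2.3-fold higher number (0.35 log units; beyond the scatter) from compound 1 to compound 3 and a 1.4-fold lower number (0.14 log units; within the scatter) from compound 2 to compound 4, 3.1-fold (0.50 log units) apart, beyond the scatter of two such steps. Both gaps come from the same set of four compounds, so they show that the two changes do not simply add together here, but they do not show why, nor what size either change would have on a third core.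

The compounds shown leave open whether another group in the place of the bromo, such as chloro, methoxy or an amine, would also shift in size between the two cores. They also leave open what happens when the fluorophenyl ring carries no fluorine at all, or carries a different group such as methyl or a carboxylic acid, and whether the same dependence on the core would appear there.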